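Bromo on the phenyl ring: cytotoxicity of compound 4

The source may report more compounds than this note shows. Statements on the series, on what has been measured and on what is new or still open speak of the compounds shown alone.

Compound 1 `O=C(/C=C\c1ccccc1)N1N=C(c2ccncc2)OC1c1c[nH]c2ccccc12` was tested in an ADME assay on HeLa cells (Homo sapiens) for cytotoxicity, read by MTT assay, with a stated time of 72 h; on this read-out lower numbers stand for stronger inhibition of growth and higher numbers for weaker inhibition of growth. In this assay compound 1 gives only a limit, > 30 ug/mL. Compound 2 `O=C(/C=C\c1cccc([N+](=O)[O-])c1)N1N=C(c2ccncc2)OC1c1c[nH]c2ccccc12` carries a nitro in place of hydrogen on an aromatic carbon; in this assay compound 2 also gives only a limit, > 30 ug/mL. Compound 3 `O=C(/C=C\c1ccc(F)cc1)N1N=C(c2ccncc2)OC1c1c[nH]c2ccccc12` carries a fluoro in place of hydrogen on an aromatic carbon; in this assay compound 3 gives only a limit as well, > 30 ug/mL. The steps a step that the two limits leave unreadable from compound 1 to compound 2 and a step that the two limits leave unreadable from compound 1 to compound 3 are therefore of unreadable size, and the same holds for a step that the two limits leave unreadable from compound 2 to compound 3, since all three values sit at the limit of > 30 ug/mL in this assay, at which 3 of the 3 values shown sit.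

Compound 4 `O=C(/C=C\c1ccc(Br)cc1)N1N=C(c2ccncc2)OC1c1c[nH]c2ccccc12` differs from compound 1 by bromo in place of hydrogen on an aromatic carbon. The change from compound 1 to compound 3 is the nearest comparison, a halogen on the same ring, and it gave no readable step. The author therefore expects compound 4 to remain at the limit in this assay, with the step that the limit leaves unreadable from compound 1 to compound 4 expected to be unreadable. The estimate for compound 4 is 45 ug/mL, within 20 ug/mL to 120 ug/mL.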

Compound 4, concentration for 50% growth inhibition: > 30 ug/mL
Compound 4 was reported as a limit (the forecaster's own chance of this, stated with the estimate: 80%); the middle value does not contradict the limit.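

Compound 4 gives only a limit in this assay, so no step between it and compound 1, compound 2 or compound 3 can be read: the limit of > 30 ug/mL in this assay, at which 4 of the 4 values shown sit.

The compounds shown leave open how strongly any of them inhibits growth, and whether changing the phenyl ring substituent alters that inhibition.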